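The source may report more compounds than this note shows. Statements on the series, on what has been measured and on what is new or still open speak of the compounds shown alone.

In a functional assay on HL-60 cells (Homo sapiens) for antiproliferative activity, read by MTT assay, with a stated time of 24 h (a higher number here means a weaker inhibitor, a lower number a stronger inhibitor), two compounds sharing one core have been tested so far. Compound 1 (`CCCCc1oc2ccccc2c1C(=O)c1ccc(OCC(=O)N2CCCCC2)cc1`) gives > 50000 nM as its reading, which is a limit of the assay and not a number. Compound 2 (`CCCCc1oc2ccccc2c1C(=O)c1ccc(OCC(=O)Nc2cccc(OC)c2)cc1`) gives > 50000 nM as its reading, again a limit and not a number. Compound 2 therefore has no number of its own, and the evidence so far amounts to the limit of > 50000 nM in this assay, at which 2 of the 2 values shown sit, and nothing more. Next comes compound 3 (`CCCCc1oc2ccccc2c1C(=O)c1ccc(OCC(=O)N[C@@H](C)c2ccccc2)cc1`), which keeps the core and carries 1-phenylethyl in place of 3-methoxyphenyl on an amide-type nitrogen and so gains a defined stereocentre. Among the compounds with values here, the only measured change that bears on this is a step that the two limits leave unreadable from compound 1 to compound 2 and it offers no size to carry over, so no change beyond the scatter is expected in this assay and another limit is the likeliest report. The expected change is a number no higher from compound 2 to compound 3 (the limit leaves the size open) on this estimate. For compound 3 the estimated value is 50000 nM with 15000 nM to 100000 nM as the expected range.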

Compound 3, half-maximal inhibitory concentration: > 50000 nM
Compound 3: only a limit was reported; the forecaster's own chance of this, stated with the estimate: 75%; the middle value sits exactly at the limit.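

In this assay compound 3 gives > 50000 nM, which is a limit of the assay and not a number. No step among compound 1, compound 2 and compound 3 can be read, and the evidence stays at a single limit: the limit of > 50000 nM in this assay, at which 3 of the 3 values shown sit.

The compounds shown leave open whether any group on the amide-type nitrogen changes antiproliferative activity at all.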